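The source may report more compounds than this note shows. Statements on the series, on what has been measured and on what is new or still open speak of the compounds shown alone.

Compound 2 `N#CC1=C(N)Oc2c(c3nc4ccccc4nc3c3ccccc23)C12C(=O)N(Cc1cnnn1-c1cccc(Cl)c1)c1ccccc12` carries a 1-(3-chlorophenyl)-1H-1,2,3-triazol-5-yl group on the shared core. In a functional assay on HCT-116 cells (Homo sapiens) for antiproliferative activity, read by MTT assay, with a stated time of 48 h (on this read-out lower numbers stand for stronger inhibition and higher numbers for weaker inhibition), compound 2 gives only a limit, > 50000 nM. In this assay compound 1 `Cc1ccccc1-n1nncc1CN1C(=O)C2(C(C#N)=C(N)Oc3c2c2nc4ccccc4nc2c2ccccc32)c2ccccc21` likewise gives only a limit, > 50000 nM. The step that the two limits leave unreadable from compound 1 to compound 2 therefore stays unreadable. Compound 3 `N#CC1=C(N)Oc2c(c3nc4ccccc4nc3c3ccccc23)C12C(=O)N(Cc1cnnn1-c1cccc(Br)c1)c1ccccc12` differs from compound 2 by bromo in place of chloro on an aromatic carbon. For the measured compounds named here, the only measured evidence that bears on this change is the limit of > 50000 nM in this assay, at which 2 of the 2 values shown sit, which gives no readable size of step. No change beyond the scatter is expected, so the step that the limit leaves unreadable from compound 2 to compound 3 is the estimate. Compound 3 is therefore expected at 70000 nM, within 30000 nM to 200000 nM, most likely again as a limit.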

Compound 3, half-maximal inhibitory concentration: > 50000 nM
Compound 3 gave a limit, no number; the forecaster's own chance of this, stated with the estimate: 85%; the middle value does not contradict the limit.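

In this assay compound 3 gives only a limit, > 50000 nM, so its steps from compound 1 and compound 2 cannot be read. The compounds shown leave open which change to the shared core, if any, would give a measurable number.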